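Adding a Bromo Group to Compound 3

The compounds below may be only part of what the source reports. "The series", "measured", "known", "first", "only" and "open" are said of these compounds alone.

Three esters sharing one core have been measured in a physicochemical assay for lipophilicity, measured as octanol-water partition; a higher number here means a more lipophilic compound, a lower number a more polar compound. Compound 3 `CC(C)[C@@H]1CC[C@@H](C)C[C@H]1OC(=O)c1ccccc1` gives 4.82. Compound 1 `COc1cccc(C(=O)O[C@@H]2C[C@H](C)CC[C@H]2C(C)C)c1` gives 4.57, which is within the scatter of compound 3. Compound 2 `CCC(=O)O[C@@H]1C[C@H](C)CC[C@H]1C(C)C` gives 3.54, clearly the lowest of the three.

The next structure, compound 4 `CC(C)[C@@H]1CC[C@@H](C)C[C@H]1OC(=O)c1ccccc1Br`, is compound 3 with one change: bromo in place of hydrogen on an aromatic carbon. This is bromo in place of hydrogen on an aromatic carbon, ortho to a large group.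

Going by the values given here, two measured steps bear on this change. The closer one also alters an aromatic carbon: hydrogen in place of methoxy gave a number 0.25 log units higher from compound 1 to compound 3 (within the scatter). The other is a much bigger swap, phenyl in place of ethyl on a carbonyl carbon, and it gave a number 1.28 log units higher from compound 2 to compound 3 (beyond the scatter).

Neither step involves bromo, so they only loosely frame the expectation. A single-atom change on the ring seems unlikely to match the large phenyl step, yet it may well exceed the small methoxy step. A moderate rise in this assay is therefore expected. The expected step is a number 0.53 log units higher from compound 3 to compound 4 (beyond the scatter). For compound 4 the estimated value is 5.35, with an expected range from 4.9 to 5.85.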

Compound 4, partition coefficient: 5.61
Estimate against measurement, compound 4: 0.26 log units below, and the stated range covers the measured number.
By their numbers in this assay, from the lowest: compound 2; then compounds 1 and 3 (each within the scatter of the next); then compound 4.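

Bromo in place of hydrogen gave a number 0.79 log units higher from compound 3 to compound 4 (beyond the scatter) in this assay and so adds one heavy atom and no hydrogen-bond donors or acceptors. The only earlier change on an aromatic carbon, hydrogen in place of methoxy, gave a number 0.25 log units higher from compound 1 to compound 3 (within the scatter) and did not clear the scatter, so this is the first change on the aromatic ring shown here to move the number clearly, at a carbon ortho to a large group. Nothing among the available measurements accounts for the rise.

With bromo as the only group tested at this carbon, and this one carbon as its only location, the compounds shown cannot say whether the rise belongs to bromo in particular or would appear with another group, such as chloro or an amine. They also leave open whether bromo on a different carbon of the aromatic ring would give a step of similar size, or whether the same change would behave alike on an ester other than this one.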